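A few compounds are considered here, and "the series" means these few. Any claim that something is new, unique, unknown or untested is made for them only; others in the source may bear on it.

Measured compounds:
- compound 1 `CC(C)=CCC/C(C)=C/CC/C(C)=C/CSC[C@H](NC(=O)CCCCCN1CCCC1)C(=O)NC1CCCCC1` — 4.48
- compound 2 `CC(C)=CCC/C(C)=C/CC/C(C)=C/CSC[C@H](NC(=O)CCCCCN1CCN(C)CC1)C(=O)NC1CCCCCCC1` — 5.88

Compound 1 gives the lower of the two numbers in a physicochemical assay for lipophilicity; a lower number here means a more polar compound, a higher number a more lipophilic compound; compound 2, with its own set of substituents, sits well above it, and the gap between the two is beyond the usual scatter. Compound 3 `CC(C)=CCC/C(C)=C/CC/C(C)=C/CSC[C@H](NC(=O)CCCCCN1CCCC1)C(=O)NC1CC1` keeps the core of compound 1 and differs from it in one place: cyclopropyl in place of cyclohexyl on an amide-type nitrogen. The group that leaves carries more heavy atoms than the group that enters, and nothing else in the molecule moves. Among the compounds with values here, no measured pair isolates this change, so its size has to be estimated rather than read off. The step of a number 1.28 log units lower from compound 1 to compound 3 (beyond the scatter) is expected to run downward in this assay and to exceed the scatter. Compound 3 is therefore expected to come in at 3.2, with a range from 2.6 to 3.8.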

Compound 3, distribution coefficient: 3.15
Beside the measured number, compound 3's estimate is 0.05 log units above it; the range from low to high includes it.
By their numbers in this assay, from the lowest: compound 3; then compound 1; then compound 2.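

In this assay, the series now has its first single-place step at this position: cyclopropyl in place of cyclohexyl on an amide-type nitrogen gives a number 1.33 log units lower from compound 1 to compound 3 (beyond the scatter). Compound 1 and compound 2 differ in more than one place, so their gap could not assign any share to this substituent; this pair shows that the read-out responds to the ring on the amide-type nitrogen alone, with 3 heavy atoms entering for 6, all carbon. No measurement on record accounts for the size of this step.

Where cyclobutyl, cyclopentyl or an open chain such as isopropyl on the same nitrogen would fall remains open. Also open, as far as these compounds go, is whether a step of this size holds when the shared core carries the other amine end group of compound 2.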